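The source may report more compounds than this note shows. Statements on the series, on what has been measured and on what is new or still open speak of the compounds shown alone.

Three compounds have been measured so far in a physicochemical assay for lipophilicity, read by HPLC, at pH 7.4; on this read-out higher numbers stand for higher lipophilicity and lower numbers for lower lipophilicity:

- compound 1 `Cc1ccc([C@@H](C)Oc2cc3onc(CCC(=O)O)c3cc2Cl)nc1` gives 2.42
- compound 2 `C[C@@H](Oc1cc2oc(=O)n(CCC(=O)O)c2cc1Cl)c1ccc(F)cn1` gives 1.98
- compound 3 `CCc1cc2oc(=O)n(CCC(=O)O)c2cc1Cl` gives 1.94

Repeated measurements of this kind never agree exactly, so small gaps carry no meaning. Compound 3 at 1.94 and compound 2 at 1.98 lie within that usual scatter of each other, and the two cannot be told apart. Compound 1 at 2.42 stands higher than compound 3, and that gap is beyond the scatter.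

Compound 4 `O=C(O)CCn1c(=O)oc2cc(OCC3CC3)c(Cl)cc21` has not been measured yet. Compared with compound 3, it carries cyclopropylmethoxy in place of ethyl on an aromatic carbon, ortho to a chloro group: cyclopropylmethoxy in place of ethyl on an aromatic carbon.

Among the measured compounds shown here, no two measured compounds differ in one place only, so no measured step shows directly what such a swap does in this assay. The expectation therefore leans on compound 2 at 1.98 and compound 3 at 1.94, whose values sit together. The expected step is a number 0.11 log units higher from compound 3 to compound 4 (within the scatter), which means no change beyond the scatter. For compound 4 the estimated value is 2.05, with an expected range from 1.65 to 2.45.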

Compound 4, distribution coefficient: 2.09
For compound 4 the middle estimate is 0.04 log units below the measured one, within the range that was stated.
By their numbers in this assay, from the lowest: compounds 3, 2 and 4 (each within the scatter of the next); then compound 1.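

Among the compounds shown here, compound 3 and compound 4 are the first pair in this set that differ in one place only, so they give the first direct reading of this position, on an aromatic carbon ortho to a chloro group. In this assay, putting cyclopropylmethoxy in place of ethyl there gives a number 0.15 log units higher from compound 3 to compound 4 (within the scatter) and so shows no change that can be told from ordinary repeat variation, even though the entering group has 5 heavy atoms, a three-membered ring and a hydrogen-bond acceptor, while ethyl has 2 heavy atoms and neither of the other two features. The data at hand offer no explanation for how little this read-out moves.

This single pair cannot show whether other groups at this position, such as an amine or a longer alkyl chain, would also leave the number within the scatter. It also leaves open whether the same swap would have so small an effect on a different core, such as the core of compound 1.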